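Shifting the Fluorine on the Ring-Nitrogen Aryl Group

The source may report more compounds than this note shows. Statements on the series, on what has been measured and on what is new or still open speak of the compounds shown alone.

Compound 1 `CCNC(=O)c1cc(Oc2ccc(NC(=O)c3cc4cccnc4n(-c4ccc(F)cc4)c3=O)cc2)ccn1`, 1130 nM
Compound 2 `CCCNC(=O)c1cc(Oc2ccc(NC(=O)c3cc4cccnc4n(-c4ccccc4)c3=O)cc2)ccn1`, 1510 nM
Compound 3 `CCCNC(=O)c1cc(Oc2ccc(NC(=O)c3cc4cccnc4n(-c4ccccc4F)c3=O)cc2)ccn1`, 2320 nM
Compound 4 `CCCNC(=O)c1cc(Oc2ccc(NC(=O)c3cc4cccnc4n(-c4ccc(F)cc4)c3=O)cc2)ccn1`, not yet measured

In a functional assay on U-87MG ATCC cells for antiproliferative activity against U-87 MG (Homo sapiens), read by MTT assay, with a stated time of 72 h (on this read-out lower numbers stand for stronger inhibition and higher numbers for weaker inhibition), compound 3 gives the highest number of the three measured compounds. Its nearest neighbour is compound 2, from which it differs only by a fluoro in place of hydrogen on an aromatic carbon; that step, a 1.5-fold higher number from compound 2 to compound 3 (0.19 log units; within the scatter), stays within the scatter. Compound 1, with its ethyl amide and 4-fluorophenyl group, lies beyond the scatter from compound 3, with compound 1 showing the lower number.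

Compound 4 is reached from compound 3 by 4-fluorophenyl in place of 2-fluorophenyl on an aromatic nitrogen. Among the compounds with values here, no measured step covers exactly this change. Within the data shown here, the only step that touches the fluorine, from compound 2 to compound 3, was small. Among the measured compounds shown here, compound 1 carries the same 4-fluorophenyl group as compound 4 but a shorter amide chain, and no step separates the two chain lengths, so its number is only a loose guide.

Compound 4 is therefore expected to land somewhere between compound 3 and compound 1, with a step of a 1.7-fold lower number from compound 3 to compound 4 (0.22 log units; within the scatter) that may well fall within the scatter. The estimated value for compound 4 in this assay is 1400 nM, within a range of 600 nM to 3200 nM.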

Compound 4, half-maximal inhibitory concentration: 960 nM
Beside the measured number, compound 4's estimate is 1.5-fold (0.16 log units) above it; measured number inside the range.
By their numbers in this assay, from the lowest: compounds 4, 1, 2 and 3 (each within the scatter of the next, the first and the last beyond it).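

Moving the fluorine on the aryl group at the ring nitrogen matters more than adding it: the change from 2-fluorophenyl to 4-fluorophenyl gives the first step at this position to clear the scatter in this assay (a 2.4-fold lower number from compound 3 to compound 4 (0.38 log units; beyond the scatter)). Set against the unsubstituted phenyl group, neither placement can be told apart, since 4-fluorophenyl gives (a 1.6-fold lower number from compound 2 to compound 4 (0.20 log units; within the scatter)) and 2-fluorophenyl gives (a 1.5-fold higher number from compound 2 to compound 3 (0.19 log units; within the scatter)), so only the two fluorinated compounds separate from each other. With the 4-fluorophenyl group held constant, the ethyl and propyl amides also cannot be told apart (a 1.2-fold lower number from compound 1 to compound 4 (0.07 log units; within the scatter)), which makes compound 1 and compound 4 equivalent within this read-out.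

The compounds shown leave open whether a chlorine or a methoxy group in place of the fluorine of the 4-fluorophenyl group would keep this standing, and whether a butyl amide or a longer chain would remain as indistinguishable as the ethyl and propyl amides do. No available evidence bears on why the place of the fluorine changes the number.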